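Phenyl to 4-methoxyphenyl: a small change at an assay limit

A few compounds are considered here, and "the series" means these few. Any claim that something is new, unique, unknown or untested is made for them only; others in the source may bear on it.

Compound 1 `C/C(=N\O)c1ccc2[nH]c(-c3ccccc3)nc2c1`: "not determined" (no result reported)
Compound 2 `C/C(=N\NC(N)=S)c1ccc2[nH]c(-c3ccccc3)nc2c1`: >= 100000 nM

These results come from an ADME assay on MT4 cells (Homo sapiens) for cytotoxicity, read by MTT assay, with a stated time of 96 h; a higher number here means that more compound is tolerated, a lower number that less compound is tolerated. Compound 1 offers no result to compare, so everything here rests on compound 2. In this assay compound 2 gives >= 100000 nM. This value is a limit of the assay and not an exact number.

Compound 3 `COc1ccc(-c2nc3cc(/C(C)=N/NC(N)=S)ccc3[nH]2)cc1` differs from compound 2 in one place: methoxy in place of hydrogen on an aromatic carbon. Put simply, methoxy takes the place of hydrogen on an aromatic carbon, para to a large group, turning phenyl into 4-methoxyphenyl.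

Among the measured compounds shown here, no pair of measured compounds shows what this change does in this assay, so any forecast is cautious. For the measured compounds named here, the only guide is compound 2 at >= 100000 nM, and compound 3 is expected to stay close to it, with no step clearly beyond the usual scatter. The expected change is an at least 1.1-fold lower number from compound 2 to compound 3 (0.04 log units; that floor lies within the scatter). The assay may well report only a limit again. For compound 3 the estimated value is 90000 nM, with an expected range from 30000 nM to 150000 nM.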

Compound 3, half-maximal cytotoxic concentration: 5000 nM
Compound 3: the middle estimate sits 18-fold (1.26 log units) above what was measured, and the stated range ends above it.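

Turning phenyl into 4-methoxyphenyl gives an at least 20-fold lower number from compound 2 to compound 3 (1.30 log units; beyond the scatter) in this assay, so this place on the ring, para to a large group, is not neutral for how much compound the cells tolerate. Compound 3 gives an exact reading of 5000 nM, which shows that a single small group here is enough to bring cytotoxicity into the range the assay can measure. The true size of the step remains unknown and could be larger than the printed minimum, since compound 2 sits at a limit of the assay and not at an exact number: the limit of >= 100000 nM in this assay, at which 1 of the 3 values shown sits.

Among the compounds shown here, with only one change at this place, it remains open whether the drop belongs to methoxy in particular or would follow from any group there, such as a hydroxyl, a chlorine atom or an amine. Going by these compounds, it is also open whether a longer chain such as ethoxy would lower the number further, or whether the same group would have a similar effect at another place on the ring.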